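This account rests on a few compounds, and the source may have more. Where it says the series, first, only, none or still open, it means among the compounds named here.

In an ADME assay on Vero cells (Chlorocebus sabaeus) for cytotoxicity, read by MTT assay, with a stated time of 48 h (a higher number here means a weaker inhibitor, a lower number a stronger inhibitor), compound 1 `O=C(OC1CCC(CN2CCN(c3cc(=O)c4cc(C(F)(F)F)cc([N+](=O)[O-])c4s3)CC2)CC1)C1CCC1` gives > 64 ug/mL, which is a limit of the assay and not a number. Compound 3 `O=C(OC1CCC(CN2CCN(c3cc(=O)c4cc(C(F)(F)F)cc([N+](=O)[O-])c4s3)CC2)CC1)c1ccncc1` gives > 64 ug/mL, which is also only a limit, so it stands at the limit of > 64 ug/mL in this assay, at which 2 of the 3 values shown sit. For the measured compounds named here, compound 2 `O=C(NC1CCC(CN2CCN(c3cc(=O)c4cc(C(F)(F)F)cc([N+](=O)[O-])c4s3)CC2)CC1)c1ccccc1` is the only one with a number, 44.3 ug/mL.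

Compound 4 `C=CC(=O)OC1CCC(CN2CCN(c3cc(=O)c4cc(C(F)(F)F)cc([N+](=O)[O-])c4s3)CC2)CC1` carries vinyl in place of pyridin-4-yl on a carbonyl carbon, a difference that counts as vinyl in place of pyridin-4-yl on a carbonyl carbon. Going by the values given here, the one measured change at this place is a step that the two limits leave unreadable from compound 1 to compound 3, and it gives no size to carry over. The other two steps change the group on the saturated ring carbon: an at least 1.4-fold lower number from compound 1 to compound 2 (0.15 log units; that floor lies within the scatter), and an at least 1.4-fold higher number from compound 2 to compound 3 (0.15 log units; that floor lies within the scatter). Neither shows a change beyond the scatter. No step beyond the scatter can therefore be firmly expected in this assay, though a modest move to a lower number remains possible. Among the compounds with values here, with compound 2 at 44.3 ug/mL as the only number, the expectation stays close to that number. The expected change is an at least 1.1-fold lower number from compound 3 to compound 4 (0.06 log units; that floor lies within the scatter). In this assay the estimate for compound 4 is 55 ug/mL, with an expected range from 22 ug/mL to 128 ug/mL.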

Compound 4, half-maximal inhibitory concentration: > 64 ug/mL
Compound 4: no number, only a limit; the forecaster's own chance of this, stated with the estimate: 55%; middle value at least 1.1-fold (0.06 log units) from the limit.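

In this assay compound 4 also gives only a limit of the assay, so the carbonyl carbon has now carried cyclobutyl, pyridin-4-yl and vinyl with the same outcome: the limit of > 64 ug/mL in this assay, at which 3 of the 4 values shown sit. The steps among these three compounds cannot be read, so no size can be given for any exchange at this place, but vinyl, with no ring, ends at the same limit as the two ring groups. For the compounds shown here, the one new step with a floor is an at least 1.4-fold higher number from compound 2 to compound 4 (0.15 log units; that floor lies within the scatter), so the (vinylcarbonyl)oxy group shows no firm separation from benzamido.

On these data alone, whether an amine or a carboxylic acid on the carbonyl carbon would give a number in this assay remains open. So does whether a benzoyloxy group on the saturated ring carbon would give a number or a limit.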